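Phenyl variation on the sulfonyl sulfur

The compounds below may be only part of what the source reports. "The series", "measured", "known", "first", "only" and "open" are said of these compounds alone.

Three measured compounds share one core and differ only in the ring on the sulfonyl sulfur. Compound 1 `CC1CCN(c2c(S(=O)(=O)c3ccc(Cl)cc3)cnc3ccc(F)cc23)CC1` carries 4-chlorophenyl and in an assay on isolated protein for displacement of a labelled ligand from metabotropic glutamate receptor 5 (Homo sapiens), with a stated time of 60 min, tested at 1 uM (a lower number here means less inhibition, a higher number more inhibition at the concentration tested (going by the name of the read-out)), compound 1 gives 80%. Compound 2 `CC1CCN(c2c(S(=O)(=O)c3cccc(C#N)c3)cnc3ccc(F)cc23)CC1` carries 3-cyanophenyl and gives 93%; compound 3 `CC1CCN(c2c(S(=O)(=O)c3cccc(Cl)c3)cnc3ccc(F)cc23)CC1` carries 3-chlorophenyl and gives 92%. Compound 3 stands second highest of the three, close to compound 2 and beyond the scatter above compound 1: the steps of a number 12 percentage points higher from compound 1 to compound 3 (beyond the scatter) and a number 13 percentage points higher from compound 1 to compound 2 (beyond the scatter) are both beyond the scatter, whereas a number 1 percentage points lower from compound 2 to compound 3 (within the scatter) lies within it.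

Compound 4 `CC1CCN(c2c(S(=O)(=O)c3ccc(F)c(F)c3)cnc3ccc(F)cc23)CC1` is not yet measured. The change is 3,4-difluorophenyl in place of 3-chlorophenyl on a sulfonyl sulfur. The measured steps bear on it only in part: the two steps away from compound 1 show that the ring on the sulfonyl sulfur can move the read-out by a modest amount, while the swap of chloro for cyano left it unchanged. Going by the values given here, no measured step exchanges chlorine for fluorine or adds a second substituent. Compound 4 is therefore expected to stay near compound 3, with the step of a number 4 percentage points lower from compound 3 to compound 4 (within the scatter) estimated to remain within the scatter. Compound 4 is expected at 88%, in the range 75% to 97%.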

Compound 4, a percentage reported as inhibition, at one concentration (the size of the read-out at that concentration, not a potency): 82%
Estimate against measurement, compound 4: 6 percentage points above, and the stated range covers the measured number.
By their numbers in this assay, from the lowest: compounds 1, 4, 3 and 2 (each within the scatter of the next, the first and the last beyond it).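

With 3,4-difluorophenyl on the sulfonyl sulfur, the ring changes in this assay no longer fall into two clear levels: a number 10 percentage points lower from compound 3 to compound 4 (within the scatter), and a number 2 percentage points higher from compound 1 to compound 4 (within the scatter), while a number 11 percentage points lower from compound 2 to compound 4 (beyond the scatter). Compound 4 therefore cannot be grouped cleanly with either compound 1 or compound 3, and only its gap to the 3-cyanophenyl ring is beyond the scatter, with a modest size. No measurement here accounts for these steps, and the separate effects of replacing chlorine with fluorine and of adding a second ring substituent cannot be told apart.

Still open, on these data alone, is how the read-out responds to a phenyl ring carrying an amine or a carboxylic acid, or to a longer alkyl chain on the sulfonyl sulfur. All four values come from a single concentration, so they give no potency ranking.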